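Aryl swap on the triazole nitrogen in the spirooxindole series

A few compounds are considered here, and "the series" means these few. Any claim that something is new, unique, unknown or untested is made for them only; others in the source may bear on it.

Measured compounds in a functional assay on HCT-116 cells (Homo sapiens) for antiproliferative activity, read by MTT assay, with a stated time of 48 h; a higher number here means a weaker inhibitor, a lower number a stronger inhibitor:
- compound 1, `N#CC1=C(N)Oc2c(c3nc4ccccc4nc3c3ccccc23)C12C(=O)N(Cc1cnnn1-c1ccc(N)cc1)c1ccccc12`: 45200 nM
- compound 2, `Cc1ccc(Cl)cc1-n1nncc1CN1C(=O)C2(C(C#N)=C(N)Oc3c2c2nc4ccccc4nc2c2ccccc32)c2ccccc21`: a limit of the assay, > 50000 nM
- compound 3, `N#CC1=C(N)Oc2c(N)cc3nc4ccccc4nc3c2C12C(=O)N(Cc1cnnn1-c1cccc(Br)c1)c1ccccc12`: 26100 nM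

Compound 3 stands as the lowest of the two numbers shown; its nearest neighbour is compound 1, which gives a number higher by an amount within the scatter. Compound 2 reaches only a limit of this assay and contributes no number.

The new compound is compound 4, `N#CC1=C(N)Oc2c(N)cc3nc4ccccc4nc3c2C12C(=O)N(Cc1cnnn1-c1c(Cl)cc(Cl)cc1Cl)c1ccccc12`. It differs from compound 3 in one place: 2,4,6-trichlorophenyl in place of 3-bromophenyl on an aromatic nitrogen.

Going by the values given here, the only measured step of the same kind, an exchange of the aryl group on the aromatic nitrogen, is an at least 1.1-fold higher number from compound 1 to compound 2 (0.04 log units; that floor lies within the scatter). That step sits at a floor set by the limit (the limit of > 50000 nM in this assay, at which 1 of the 3 values shown sits), so it shows at most a small rise and nothing about size beyond the scatter. Among the compounds with values here, no measured step covers a trichlorophenyl or a move away from a halophenyl on this nitrogen.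

On this evidence no step beyond the scatter is expected for compound 4 in this assay; if anything a slight rise, as seen from compound 1 to compound 2. Compound 4 is therefore estimated at 35000 nM, with a range from 15000 nM to 80000 nM. That estimate corresponds to the expected step of a 1.3-fold higher number from compound 3 to compound 4 (0.13 log units; within the scatter).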

Compound 4, half-maximal inhibitory concentration: 12100 nM
Estimate against measurement, compound 4: 2.9-fold (0.46 log units) above, outside the stated range (below it).
By their numbers in this assay, from the lowest: compound 4; then compounds 3 and 1 (each within the scatter of the next). At a limit, above all of these: compound 2.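

In this assay, 2,4,6-trichlorophenyl in place of 3-bromophenyl on the aromatic nitrogen of the triazole-type ring gives a 2.2-fold lower number from compound 3 to compound 4 (0.33 log units; beyond the scatter), a modest step but one beyond the scatter. Going by these compounds alone, this is the first exchange at this nitrogen with a readable size, as the earlier aryl exchange ended in a limit of the assay for compound 2 and cannot be read as a step of known size. The larger halophenyl is therefore accepted at this position on the core of compound 3 and goes with a lower number, although nothing shown gives a reason for the change.

With a single exchange on this core, the shift cannot be assigned to the number of halogen atoms, their placement on the ring or chlorine against bromine, and a dichlorophenyl, a monochlorophenyl and an unsubstituted phenyl on the same core would separate these readings. Also open, as far as these compounds go, is how this core responds to a non-halogen aryl group, such as a phenyl carrying an amine or a carboxylic acid.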